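Sulfamate Series: Furan Replaced by a Dimethylamino Chain

The compounds below may be only part of what the source reports. "The series", "measured", "known", "first", "only" and "open" are said of these compounds alone.

Compound 1, `NS(=O)(=O)Oc1ccc2c(c1)CN(C(=O)c1ccc(N(Cc3ccccc3)Cc3ccco3)cc1)CC2`: 90.8%
Compound 2, `CCN(Cc1ccncc1)c1ccc(C(=O)N2CCc3ccc(OS(N)(=O)=O)cc3C2)cc1`: 47%
Compound 3, `CCN(Cc1ccc(F)cc1)c1cccc(C(=O)N2CCc3ccc(OS(N)(=O)=O)cc3C2)c1`: 10.9%

In an assay on HEK293 cells for inhibition of Steryl-sulfatase (Homo sapiens), tested at 0.1 uM (on this read-out higher numbers stand for a stronger effect at the one concentration tested and lower numbers for a weaker effect), compound 1 gives 90.8%, the highest of the three numbers; compound 2 sits lower by a margin beyond the scatter, and compound 3 lies furthest off, also beyond the scatter. Compound 4, `CN(C)CCCN(Cc1ccccc1)c1ccc(C(=O)N2CCc3ccc(OS(N)(=O)=O)cc3C2)cc1`, has not yet been measured in this assay. It departs from compound 1 by a single change: 2-(dimethylamino)ethyl in place of furan-2-yl on a saturated chain carbon bound to a nitrogen on an aromatic ring. Within the data shown here, no pair of measured compounds isolates this change, so its size is open. Since compound 1 gives 90.8% with the shared core and benzyl group that compound 4 keeps, a moderate fall rather than a collapse is expected. The step from compound 1 to compound 4 is estimated as a number 25.8 percentage points lower from compound 1 to compound 4 (beyond the scatter). Compound 4 is expected to give about 65%, within 30% to 92%.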

Compound 4, a percentage reported as inhibition, at one concentration (the size of the read-out at that concentration, not a potency): 16.2%
Compound 4: middle estimate off by 48.8 percentage points, on the high side; measured number outside the range, below it.
By their numbers in this assay, from the lowest: compounds 3 and 4 (each within the scatter of the next); then compound 2; then compound 1.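

In this assay, 2-(dimethylamino)ethyl in place of furan-2-yl on a saturated chain carbon bound to a nitrogen on an aromatic ring gives a number 74.6 percentage points lower from compound 1 to compound 4 (beyond the scatter) in one step. The position is therefore sensitive to this change, although the shared core and benzyl group stay the same and the two groups agree in their counts of heavy atoms, hydrogen-bond donors and acceptors. No measurement at hand bears on the reason for this fall.

The compounds shown do not separate losing the furan ring from gaining the dimethylamino group. Going by these compounds, whether a (thiophen-2-yl)methyl group or a plain butyl chain at this place would hold the number remains open.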